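Swapping a ring group on compound 1's sulfur-bound carbon

This account rests on a few compounds, and the source may have more. Where it says the series, first, only, none or still open, it means among the compounds named here.

Compound 1 `C[C@@]1(O)CC(=O)OC(CSc2nc(-c3ccccc3Cl)c(-c3ccccc3Cl)[nH]2)C1`: 140 nM
Compound 2 `CC(O)(CC(=O)OC(C)(C)C)CC(O)CSc1nc(-c2ccc(Cl)cc2)c(-c2ccc(Cl)cc2)[nH]1`: 250 nM

In an assay on microsomes from liver for inhibition of sterol O-acyltransferase 1 (Rattus norvegicus) (on this read-out higher numbers stand for weaker inhibition and lower numbers for stronger inhibition), compound 1 gives 140 nM, the lower of the two numbers; compound 2, at 250 nM, lies within the usual scatter of it. Compound 3 `CC1=CC(=O)OC(CSc2nc(-c3ccccc3Cl)c(-c3ccccc3Cl)[nH]2)C1` has not been measured. It differs from compound 1 by a group of 8 heavy atoms (6 carbon, 2 oxygen; one six-membered non-aromatic ring with 1 hetero atom) in place of a group of 9 heavy atoms (6 carbon, 3 oxygen; one six-membered non-aromatic ring with 1 hetero atom), on a saturated chain carbon bound to a sulfur: the ring that leaves carries one hydrogen-bond donor, the ring that enters none, and one more double bond outside aromatic rings. Going by the values given here, no measured pair shows this kind of change, so the step of a 1.4-fold higher number from compound 1 to compound 3 (0.15 log units; within the scatter) is expected to stay small in this assay, perhaps slightly toward weaker inhibition. Compound 3 is estimated at 200 nM, within 70 nM to 600 nM.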

Compound 3, half-maximal inhibitory concentration: 1700 nM
Beside the measured number, compound 3's estimate is 8.5-fold (0.93 log units) below it; the whole stated range lies below it.
By their numbers in this assay, from the lowest: compounds 1 and 2 (each within the scatter of the next); then compound 3.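

Swapping the ring on the saturated chain carbon bound to a sulfur gives a 12-fold higher number from compound 1 to compound 3 (1.08 log units; beyond the scatter) in this assay, so a small change to this ring can matter greatly. The entering ring has no hydrogen-bond donor and one more double bond outside aromatic rings, and this single step cannot separate those two differences. No available evidence explains the size of the step. On these data alone, it remains open whether an amine or a methoxy group in place of the ring's hydroxyl would behave like the ring of compound 1, and whether a saturated ring without any hydroxyl would.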